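Swapping Trifluoromethyl for Chloro on the Urea Aryl Ring

This account rests on a few compounds, and the source may have more. Where it says the series, first, only, none or still open, it means among the compounds named here.

Compound 1 `COc1cc2cc(Oc3ccc(NC(=O)Nc4cccc(C(F)(F)F)c4)cc3)c(C)nc2cc1OC` and compound 2 `COc1cc2cc(Oc3ccc(NC(=O)Nc4ccc(Cl)c(C(F)(F)F)c4)cc3)c(C)nc2cc1OC` share one core and differ only in a single chloro group. In a functional assay on RPMI-8226 cells (Homo sapiens) for inhibition, read by sulforhodamine B assay, with a stated time of 48 h (a lower number here means a stronger inhibitor of growth, a higher number a weaker inhibitor of growth), compound 1 gives 1050 nM and compound 2 gives 636 nM. The step of a 1.7-fold lower number from compound 1 to compound 2 (0.22 log units; within the scatter) is the only measured step, and compound 2 holds the lower of the two numbers shown, with compound 1 its nearest neighbour, the gap lying within the scatter. Compound 3 `COc1cc2cc(Oc3ccc(NC(=O)Nc4ccc(Cl)c(Cl)c4)cc3)c(C)nc2cc1OC` arises from compound 2 by chloro in place of trifluoromethyl on an aromatic carbon. Among the measured compounds shown here, no measured step tests this exact swap: the one step, a 1.7-fold lower number from compound 1 to compound 2 (0.22 log units; within the scatter), added a chloro group rather than replacing a trifluoromethyl, and was itself small. With nothing pointing to a large effect, compound 3 is expected to sit close to compound 2 in this assay, the estimated step of a 1.4-fold higher number from compound 2 to compound 3 (0.15 log units; within the scatter) being modest. For compound 3 the estimate is 900 nM, with a range from 350 nM to 2500 nM.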

Compound 3, concentration for 50% growth inhibition: 1620 nM
Compound 3: middle estimate off by 1.8-fold (0.26 log units), on the low side; measured number inside the range.
By their numbers in this assay, from the lowest: compounds 2, 1 and 3 (each within the scatter of the next, the first and the last beyond it).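

In this assay, replacing the trifluoromethyl with chloro gives a 2.5-fold higher number from compound 2 to compound 3 (0.41 log units; beyond the scatter) and so moves the number beyond the scatter, which the added chloro of the earlier step did not do; this position therefore responds to which group it carries. Going from 3-(trifluoromethyl)phenyl to 3,4-dichlorophenyl gives a 1.5-fold higher number from compound 1 to compound 3 (0.19 log units; within the scatter) and stays within the scatter, so these two rings cannot be told apart here, and only the pairing of chloro with trifluoromethyl on one ring stands apart, and only from 3,4-dichlorophenyl. Nothing available explains why the swap has this effect.

Going by these compounds, whether an amine, a nitrile or a methoxy group at this position would give a lower or higher number remains open. Also open, on these data alone, is whether the same swap behaves alike on a ring without the neighbouring chloro.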